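The source may hold more compounds than are shown below. What is called first, only, known or untested is meant among the compounds shown, and "the series" means these compounds.

In a functional assay on A549 cells (Homo sapiens) for cytotoxicity, read by WST assay, with a stated time of 24 h (on this read-out lower numbers stand for stronger inhibition and higher numbers for weaker inhibition), compound 1 `COc1ccc2c(/C=C(\C#N)C(=O)c3c[nH]c4cc(OC)ccc34)c[nH]c2c1` gives 1900 nM and compound 3 `N#C/C(=C\c1c[nH]c2cc(F)ccc12)C(=O)c1c[nH]c2ccccc12` gives 17000 nM as the higher of these two numbers. Compound 2 `N#C/C(=C\c1c[nH]c2cc(F)ccc12)C(=O)c1c[nH]c2cc(F)ccc12` stands at > 50000 nM as a limit of the assay, not a number. Hydrogen in place of fluoro on an aromatic carbon brings an at least 2.9-fold lower number from compound 2 to compound 3 (0.46 log units; beyond the scatter) as the only measured step at that carbon. Compound 4 `COc1ccc2c(C(=O)/C(C#N)=C/c3c[nH]c4cc(F)ccc34)c[nH]c2c1` changes the same carbon again, with methoxy in place of hydrogen on an aromatic carbon as the difference: methoxy in place of hydrogen. Compound 1 at 1900 nM also carries methoxy there, though it differs elsewhere too, so a lower number than for compound 3 is expected. The expected change is a 2.8-fold lower number from compound 3 to compound 4 (0.45 log units; beyond the scatter) in size, and it remains uncertain. For compound 4 the estimate is 6000 nM with an expected range from 2000 nM to 18000 nM around it.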

Compound 4, half-maximal inhibitory concentration: 2400 nM
Estimate against measurement, compound 4: 2.5-fold (0.40 log units) above; measured number inside the range.
By their numbers in this assay, from the lowest: compounds 1 and 4 (each within the scatter of the next); then compound 3. At a limit, above all of these: compound 2.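

Methoxy at this carbon now has a measured step of its own, a 7.1-fold lower number from compound 3 to compound 4 (0.85 log units; beyond the scatter) when it replaces hydrogen. Compound 2, with fluoro at this carbon, sits at a limit and not a number, so methoxy in its place gives only a bound, an at least 20-fold lower number from compound 2 to compound 4 (1.31 log units; beyond the scatter) at this carbon: the limit of > 50000 nM in this assay, at which 1 of the 4 values shown sits. At a different aromatic carbon, the swap of methoxy for fluoro gives a 1.3-fold higher number from compound 1 to compound 4 (0.10 log units; within the scatter) in this comparison, so there the two groups cannot be told apart.

On these data alone, whether an amine or a carboxylic acid at the first carbon would lower the number further remains open. So does whether a longer chain than methoxy would be tolerated there.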